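Moving the Fluorine on the Sulfonyl Aryl Group

The compounds below may be only part of what the source reports. "The series", "measured", "known", "first", "only" and "open" are said of these compounds alone.

Compound 1 `O=C(NCc1ccc(CNS(=O)(=O)c2cccc3ccccc23)cc1)c1ccc(CNc2ncccn2)cc1`: 1000 nM
Compound 2 `O=C(NCc1ccc(CNS(=O)(=O)c2cccc(Cl)c2)cc1)c1ccc(CNc2ncccn2)cc1`: 1 nM
Compound 3 `O=C(NCc1ccc(CNS(=O)(=O)c2cccc(F)c2)cc1)c1ccc(CNc2ncccn2)cc1`: 1000 nM

The three measured compounds share one core and differ only in the aryl group attached to the sulfonyl sulfur, and all were tested in an assay on MDA-MB-231 cells for binding affinity to C-X-C chemokine receptor type 4 (Homo sapiens), read by microscopy, with stated times of 10 min and 30 min; a lower number here means that less compound is needed, a higher number that more compound is needed for the effect. Compound 3 stands level with compound 1, and together they give the highest numbers of the three; compound 2 is the furthest from compound 3, as a 1000-fold higher number from compound 2 to compound 3 (3.00 log units; beyond the scatter) shows. The other steps are a 1000-fold lower number from compound 1 to compound 2 (3.00 log units; beyond the scatter) and no change at the digits printed from compound 1 to compound 3 (within the scatter).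

Compound 4 `O=C(NCc1ccc(CNS(=O)(=O)c2ccccc2F)cc1)c1ccc(CNc2ncccn2)cc1` differs from compound 3 in this way: 2-fluorophenyl in place of 3-fluorophenyl on a sulfonyl sulfur. Going by the values given here, none of the measured steps moves a substituent from one place on the ring to another; each exchanges one aryl group for a different one. Those steps show that this assay responds strongly to what sits on the sulfonyl sulfur, so the change in compound 4 cannot be taken as harmless, but nothing measured points to a direction. Compound 4 is therefore expected to give about 1000 nM, with a wide range from 100 nM to 3000 nM. The expected step is no change at the digits printed from compound 3 to compound 4 (within the scatter).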

Compound 4, effective concentration (reported as EC, without a stated level of effect): 1000 nM
Compound 4: middle estimate and measured number agree at the digits printed; the range from low to high includes it.
By their numbers in this assay, from the lowest: compound 2; then compounds 1, 3 and 4 (each within the scatter of the next).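

Moving the fluorine, the first change here that keeps the same atoms and only joins them differently, gives no measurable shift in this assay (no change at the digits printed from compound 3 to compound 4 (within the scatter)), so for fluorine these two places on the ring cannot be told apart. The distance from the chlorine compound stays just as large (a 1000-fold higher number from compound 2 to compound 4 (3.00 log units; beyond the scatter)), and the 2-fluorophenyl group matches the much bigger naphthalen-1-yl group in its number (no change at the digits printed from compound 1 to compound 4 (within the scatter)); compounds 1, 3 and 4 therefore form one level, and only the 3-chlorophenyl group of compound 2 stands apart from it. Nothing measured here gives a reason why the two fluorine placements match or why chloro in compound 2 behaves so differently from fluoro in compound 3.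

The compounds shown leave open whether the low number of compound 2 at 1 nM belongs to chloro alone or would also appear with bromo, methyl or methoxy in its place. They also leave open whether chloro, unlike fluoro, depends on where it sits on the ring.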